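The source may hold more compounds than are shown below. What is called first, only, known or untested is meant among the compounds shown, and "the series" means these compounds.

Working notes on the sulfonyl series

Of the compounds shown here, three have been measured in an ADME assay on microsomes from liver (Rattus norvegicus) for metabolic stability, with a stated time of 10 min; on this read-out lower numbers stand for a less stable compound and higher numbers for a more stable compound. Compound 1 `CC(C)S(=O)(=O)NC(=O)c1ccc(Nc2nc(NC3(c4ccc(Cl)cc4)CC3)nc(OCC(F)(F)F)n2)cc1` gives 96% in this assay. Compound 2 `CC(C)(C)OC(=O)NCCS(=O)(=O)NC(=O)c1ccc(Nc2nc(NC3(c4ccc(Cl)cc4)CC3)nc(OCC(F)(F)F)n2)cc1` gives 93% in this assay. Among the measured compounds shown here, compound 3 `CC(C)OC(=O)NCCS(=O)(=O)NC(=O)c1ccc(Nc2nc(NC3(c4ccc(Cl)cc4)CC3)nc(OCC(F)(F)F)n2)cc1` gives 73% in this assay, the lowest of the three numbers; its steps to compound 2 and to compound 1 both lie beyond the scatter, so compound 3 is the least stable compound measured so far.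

The measured steps: a number 3 percentage points lower from compound 1 to compound 2 (within the scatter); a number 23 percentage points lower from compound 1 to compound 3 (beyond the scatter); a number 20 percentage points lower from compound 2 to compound 3 (beyond the scatter).

Compound 4 `CC(C)NC(=O)NCCS(=O)(=O)NC(=O)c1ccc(Nc2nc(NC3(c4ccc(Cl)cc4)CC3)nc(OCC(F)(F)F)n2)cc1` differs from compound 3 by isopropylamino in place of isopropoxy on a carbonyl carbon. For the measured compounds named here, none of the measured steps touches the carbonyl carbon itself; the only step on the carbamate end of the chain, a number 20 percentage points lower from compound 2 to compound 3 (beyond the scatter), concerns the alkyl on the oxygen, not the exchange of that oxygen for a nitrogen. Going by the values given here, no step in the set therefore bears directly on the change from compound 3 to compound 4, and the set gives no basis for a direction. The working expectation is a step of a number 3 percentage points higher from compound 3 to compound 4 (within the scatter) in this assay, that is, no change that can be trusted beyond the scatter. On that basis compound 4 is estimated at 76% in this assay, within a range from 52% to 94%.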

Compound 4, percent of the compound remaining: 97%
Compound 4: middle estimate off by 21 percentage points, on the low side; the measured number lies above the stated range.
By their numbers in this assay, from the lowest: compound 3; then compounds 2, 1 and 4 (each within the scatter of the next).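

In this assay, among the compounds shown here, the exchange of isopropoxy for isopropylamino on the carbonyl carbon gives a number 24 percentage points higher from compound 3 to compound 4 (beyond the scatter); this is the first step at that atom itself, and it shows that the number responds to the atom bound to this carbonyl carbon, not only to the alkyl carried on it. The other two new steps place compound 3 alone among the chain-bearing compounds, with isopropylamino in place of tert-butoxy giving a number 4 percentage points higher from compound 2 to compound 4 (within the scatter) and the whole 2-((isopropylcarbamoyl)amino)ethyl in place of isopropyl on the sulfonyl sulfur giving a number 1 percentage points higher from compound 1 to compound 4 (within the scatter), so a substituted chain on the sulfonyl sulfur does not by itself go with a lower number in this set. Nothing at hand accounts for the step from isopropoxy to isopropylamino.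

Open, from the compounds shown here alone, is whether the isopropylamino result carries over to other groups on this carbonyl carbon, such as tert-butylamino, the direct partner of the tert-butoxy in compound 2. Equally open, going by these compounds, is how the number responds when the carbonyl end of the chain gives way to a free amine or a carboxylic acid, or when a longer chain stands on the sulfonyl sulfur.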